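The source may report more compounds than this note shows. Statements on the series, on what has been measured and on what is new or still open speak of the compounds shown alone.

Compound 3 `CC(C)[C@H](NC(=O)COc1cccc2ccccc12)C(=O)N[C@@H](CC(=O)O)C(=O)COc1cccc2cccnc12` belongs to a small set of close relatives that differ only in the aromatic group attached on an oxygen on a saturated carbon. In a functional assay on Jurkat cells (Homo sapiens) for inhibition (a higher number here means a weaker inhibitor, a lower number a stronger inhibitor), compound 3 gives only a limit of the assay, > 200000 nM. Compound 1 `CCOC(=O)c1c(C)noc1OCC(=O)[C@H](CC(=O)O)NC(=O)[C@@H](NC(=O)COc1cccc2ccccc12)C(C)C` likewise reaches only a limit, > 200000 nM. Compound 2 `CC(C)[C@H](NC(=O)COc1cccc2ccccc12)C(=O)N[C@@H](CC(=O)O)C(=O)COc1ccnc(C(F)(F)F)n1` gives a readable number, 37000 nM. The measured steps show how much this group matters: an at least 5.4-fold lower number from compound 1 to compound 2 (0.73 log units; beyond the scatter), an at least 5.4-fold higher number from compound 2 to compound 3 (0.73 log units; beyond the scatter), while a step that the two limits leave unreadable from compound 1 to compound 3. Compound 4 `CC(C)[C@H](NC(=O)COc1cccc2ccccc12)C(=O)N[C@@H](CC(=O)O)C(=O)COn1nnc2ccccc2c1=O` carries a group of 11 heavy atoms (7 carbon, 3 nitrogen, 1 oxygen; one six-membered aromatic ring of carbon only, one six-membered aromatic ring with 3 hetero atoms) in place of a group of 10 heavy atoms (9 carbon, 1 nitrogen; one six-membered aromatic ring of carbon only, one six-membered aromatic ring with 1 hetero atom), on an oxygen on a saturated carbon. Among the measured compounds shown here, none of the measured steps covers this new group, so a shift of similar size in either direction is plausible, and only a lower number would be readable from the limit. Compound 4 is therefore expected at about 60000 nM, within 8000 nM to 300000 nM, which means an expected at least 3.3-fold lower number from compound 3 to compound 4 (0.52 log units; beyond the scatter).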

Compound 4, half-maximal inhibitory concentration: 137000 nM
Estimate against measurement, compound 4: 2.3-fold (0.36 log units) below; the measured number falls inside the stated range.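

In this assay compound 4 gives a readable number with a two-ring group on the oxygen on a saturated carbon, yet the single-ring 2-(trifluoromethyl)pyrimidin-4-yl group still does better: a 3.7-fold higher number from compound 2 to compound 4 (0.57 log units; beyond the scatter). The other two steps are an at least 1.4-fold lower number from compound 3 to compound 4 (0.16 log units; that floor lies within the scatter) and an at least 1.4-fold lower number from compound 1 to compound 4 (0.16 log units; that floor lies within the scatter), and neither floor alone shows a real gain. Both remain floors because of the limit: the limit of > 200000 nM in this assay, at which 2 of the 4 values shown sit.

Going by these compounds, it remains open whether the trifluoromethyl group accounts for the lower number of compound 2. A plain pyrimidin-4-yl or phenyl group at this place could separate the roles of the substituent and the ring.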